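Hydrazone aryl variation in a cytotoxicity series

The source may hold more compounds than are shown below. What is called first, only, known or untested is meant among the compounds shown, and "the series" means these compounds.

Measured so far:
compound 1 `CN(C)CCn1cnnc1-c1cc(Oc2ccc(NC(=O)N/N=C/c3cccc(Cl)c3Cl)cc2F)ccn1` — 51 nM
compound 2 `CN(C)CCn1cnnc1-c1cc(Oc2ccc(NC(=O)N/N=C/c3ccc(O)cc3)cc2F)ccn1` — 820 nM
compound 3 `CN(C)CCn1cnnc1-c1cc(Oc2ccc(NC(=O)N/N=C/c3cc(Br)c(O)c(Br)c3)cc2F)ccn1` — 4320 nM

In a functional assay on MKN-45 cells (Homo sapiens) for cytotoxicity, read by MTT assay, with a stated time of 72 h (a higher number here means a weaker inhibitor, a lower number a stronger inhibitor), compound 3 gives the highest number of the three, standing a 5.3-fold higher number from compound 2 to compound 3 (0.72 log units; beyond the scatter) and an 85-fold higher number from compound 1 to compound 3 (1.93 log units; beyond the scatter). The unmeasured compound 4 `Cc1cc(/C=N/NC(=O)Nc2ccc(Oc3ccnc(-c4nncn4CCN(C)C)c3)c(F)c2)cc(C)c1O` differs from compound 3 in one place: 4-hydroxy-3,5-dimethylphenyl in place of 3,5-dibromo-4-hydroxyphenyl on a carbon with a double bond to nitrogen. For the measured compounds named here, no measured step makes exactly this exchange, so the closest guidance is the step that put the 3,5-dibromo-4-hydroxyphenyl in place of the 4-hydroxyphenyl, a 5.3-fold higher number from compound 2 to compound 3 (0.72 log units; beyond the scatter), a modest rise. Compound 4 keeps the 4-hydroxyphenyl pattern of compound 2 but adds two methyl groups where compound 3 carries bromines, so the number is expected to fall between those of compound 2 and compound 3, most likely nearer compound 3. The expected step is a 2.2-fold lower number from compound 3 to compound 4 (0.33 log units; beyond the scatter), small and possibly within the scatter. For compound 4 in this assay the estimate is 2000 nM, with a range from 500 nM to 8000 nM.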

Compound 4, half-maximal inhibitory concentration: 1510 nM
Compound 4: middle estimate off by 1.3-fold (0.12 log units), on the high side; measured number inside the range.
By their numbers in this assay, from the lowest: compound 1; then compounds 2 and 4 (each within the scatter of the next); then compound 3.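

In this assay, 4-hydroxy-3,5-dimethylphenyl in place of 3,5-dibromo-4-hydroxyphenyl gives a 2.9-fold lower number from compound 3 to compound 4 (0.46 log units; beyond the scatter), so the two groups at this position are not interchangeable. With a 1.8-fold higher number from compound 2 to compound 4 (0.27 log units; within the scatter), the dimethyl compound cannot be told apart from the unsubstituted 4-hydroxyphenyl, so among these phenols only the dibromo compound stands clearly apart, and adding two groups to the ring does not by itself move the number beyond the scatter. The 2,3-dichlorophenyl remains far from this phenol as well, with a 30-fold higher number from compound 1 to compound 4 (1.47 log units; beyond the scatter).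

No supporting data explain the difference between the bromine and methyl compounds or the distance of the dichlorophenyl compound from the phenols. The compounds shown also leave open how a dichlorophenyl ring carrying a hydroxyl, or a phenyl ring bearing a methoxy group or an amine, would read at this position.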